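The source may report more compounds than this note shows. Statements on the series, on what has been measured and on what is new or still open speak of the compounds shown alone.

Measured so far in a functional assay on HCT-116 cells (Homo sapiens) for inhibition, read by MTT assay, with a stated time of 2 days, tested at 100 uM; a higher number here means more inhibition of growth at the concentration tested, a lower number less inhibition of growth: compound 1 `CNC(=O)c1cc(Oc2ccc3nc(NC(=O)c4cc(Cl)cc(Cl)c4)sc3c2)ccn1` gives 15.8%; compound 2 `CNC(=O)c1cc(Oc2ccc3nc(NC(=O)Nc4ccc(Br)cc4)sc3c2)ccn1` gives 80%.

Compound 2 stands highest of the two numbers in this assay; its nearest neighbour is compound 1, and the step of a number 64.2 percentage points higher from compound 1 to compound 2 (beyond the scatter) lies beyond the scatter. That step, however, exchanges the whole aryl amide for an aryl urea and says nothing about a halogen swap within the urea.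

Compound 3 `CNC(=O)c1cc(Oc2ccc3nc(NC(=O)Nc4ccc(F)cc4)sc3c2)ccn1` differs from compound 2 only in that (fluoro in place of bromo on an aromatic carbon), the place being on an aromatic carbon of a six-membered aromatic ring of carbon only, para to a large group. Within the data shown here, no measured step covers this exchange, so no direction can be read from the data. The step of a number 10 percentage points lower from compound 2 to compound 3 (within the scatter) is therefore expected to be small, most likely within the scatter. Compound 3 is estimated at 70%, with a range from 45% to 90%.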

Compound 3, percent growth inhibition at one concentration: 83.8%
For compound 3 the middle estimate is 13.8 percentage points below the measured one; low and high end bracket the measured number.
By their numbers in this assay, from the lowest: compound 1; then compounds 2 and 3 (each within the scatter of the next).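

In this assay, fluoro in place of bromo on an aromatic carbon para to a large group gives a number 3.8 percentage points higher from compound 2 to compound 3 (within the scatter), so the two halogens cannot be told apart at this place. The large gain over the amide is also not tied to bromo: with the 4-fluorophenyl urea, the change reads a number 68 percentage points higher from compound 1 to compound 3 (beyond the scatter), of similar size to the earlier a number 64.2 percentage points higher from compound 1 to compound 2 (beyond the scatter). Nothing available bears on why the read-out holds across this halogen exchange.

On these data alone, whether a methoxy group, an amine or a carboxylic acid at the same carbon would keep this level of growth inhibition remains open. Also open, as far as these compounds go, is how much of the gain belongs to the urea link and how much to the aryl substitution, a question that a 3,5-dichlorophenyl urea would address.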